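A few compounds are considered here, and "the series" means these few. Any claim that something is new, unique, unknown or untested is made for them only; others in the source may bear on it.

Measured compounds:
- compound 1, `O=C(N1CCCC[C@@H]1COCc1ccccc1)n1cc(-c2ccc(-c3ccccc3)cc2)nn1`, 79.4 nM 
- compound 2, `O=C(N1CCC=C[C@@H]1COCc1ccccc1)n1cc(-c2ccccc2)nn1`, 158 nM 

The account follows the step from compound 2 to compound 3. In an assay on HEK293 cells for inhibition of diacylglycerol lipase-alpha (Homo sapiens), read by colorimetric assay, with stated times of 30 min, 60 s and 20 min (a higher number here means a weaker inhibitor, a lower number a stronger inhibitor), compound 2 gives 158 nM, and in this assay compound 1 gives 79.4 nM; the two values lie within the usual scatter of each other, so the numbers shown do not separate the two compounds. Compound 3, `O=C(N1CCC=C[C@@H]1COCc1ccccc1)n1cc(-c2ccc([N+](=O)[O-])cc2)nn1`, has not been measured in this assay. It differs from compound 2 in one place: nitro in place of hydrogen on an aromatic carbon. For the measured compounds named here, no measured pair in this set shows the same change, so there is no step from which its size can be read. The two measured values show that a larger group on this ring did not move the number beyond the scatter, and on that basis compound 3 is expected to give a number close to that of compound 2, with the step of a 1.3-fold lower number from compound 2 to compound 3 (0.12 log units; within the scatter) expected to stay within the scatter. Compound 3 is thus estimated at 120 nM in this assay, within a range of 40 nM to 400 nM.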

Compound 3, half-maximal inhibitory concentration: 15.9 nM
Estimate against measurement, compound 3: 7.5-fold (0.88 log units) above; measured number outside the range, below it.
By their numbers in this assay, from the lowest: compound 3; then compounds 1 and 2 (each within the scatter of the next).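

In this assay, the change from phenyl to 4-nitrophenyl gives a 9.9-fold lower number from compound 2 to compound 3 (1.00 log units; beyond the scatter), so a single group on this aromatic carbon, para to a large group, moves the number beyond the scatter. The earlier compounds shown here could not show this: compound 1 and compound 2 differ in more than one place, so no step between them could be read, whereas this pair differs only by nitro in place of hydrogen. Nothing shown here bears on why this one change has a step of this size.

The compounds shown leave open whether the step belongs to nitro in particular or would also appear with another group on the same carbon, such as an amine, a carboxylic acid or a nitrile. For the compounds shown here, they also leave open whether nitro would give a step of similar size on the core of compound 1, since this single pair is the only evidence for the change and it rests on the core shared by compound 2 and compound 3.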